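Shortening the sulfonamide chain on a bicyclic imidazole core

This account rests on a few compounds, and the source may have more. Where it says the series, first, only, none or still open, it means among the compounds named here.

Of the compounds shown here, three sharing one core have been measured in a functional assay on CHO cells for agonist activity at Alpha-1A adrenergic receptor (Homo sapiens), read by FLIPR and calcium flux; a higher number here means a larger maximal response, a lower number a smaller maximal response. Compound 1 `Cc1n[nH]cc1-c1cccc2c1CCC2c1ncc[nH]1` gives 91%, compound 2 `CCCS(=O)(=O)Nc1cccc2c1CCC2c1ncc[nH]1` gives 54%, and compound 3 `c1cc(-c2nccs2)c2c(c1)C(c1ncc[nH]1)CC2` gives 64%. Compound 3 thus stands second highest of the three: its value sits within the scatter of compound 2, while compound 1 lies clearly above it, as the step of a number 27 percentage points lower from compound 1 to compound 3 (beyond the scatter) shows.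

Compound 4 `CCS(=O)(=O)Nc1cccc2c1CCC2c1ncc[nH]1` is the next compound, still unmeasured. Its change from compound 3 is (ethylsulfonyl)amino in place of 1,3-thiazol-2-yl on an aromatic carbon.

The most direct guide is the reverse of the step of a number 10 percentage points higher from compound 2 to compound 3 (within the scatter), where (propylsulfonyl)amino was exchanged for 1,3-thiazol-2-yl with no shift beyond the scatter. Compound 4 carries (ethylsulfonyl)amino, differing from compound 2 only by one carbon in the chain. The two larger steps, a number 37 percentage points lower from compound 1 to compound 2 (beyond the scatter) and a number 27 percentage points lower from compound 1 to compound 3 (beyond the scatter), both fall from compound 1 and show that the sulfonamide and the thiazole end at similar levels in this assay.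

Compound 4 is therefore estimated at 54%, with a range from 38% to 70%. The expected step is a number 10 percentage points lower from compound 3 to compound 4 (within the scatter), a change that stays within the scatter, because the measured step of a number 10 percentage points higher from compound 2 to compound 3 (within the scatter) did so too.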

Compound 4, largest response reached (Emax), in percent of the reference or control that the assay uses: 86%
Compound 4: the middle estimate sits 32 percentage points below what was measured, and the stated range ends below it.
By their numbers in this assay, from the lowest: compounds 2 and 3 (each within the scatter of the next); then compounds 4 and 1 (each within the scatter of the next).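

Within this assay, replacing a methyl with hydrogen on the sulfonamide chain, which turns (propylsulfonyl)amino into (ethylsulfonyl)amino, gives a number 32 percentage points higher from compound 2 to compound 4 (beyond the scatter), so a small trim to this chain can change the maximal response considerably. The group on this aromatic carbon therefore cannot be judged simply as a sulfonamide: the ethyl version gives a number 22 percentage points higher from compound 3 to compound 4 (beyond the scatter) against the 1,3-thiazol-2-yl compound, while against the 3-methyl-1H-pyrazol-4-yl compound it gives a number 5 percentage points lower from compound 1 to compound 4 (within the scatter), so the two cannot be told apart here. The closeness of sulfonamide and thiazole seen earlier thus holds for the propyl chain but not for the ethyl chain, and no supporting measurement is available to explain the jump.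

With only two chain lengths, the compounds shown leave open whether the response would stay high with a still shorter methylsulfonylamino group or fall further with a longer butylsulfonylamino chain. They also leave open whether the sulfonyl itself matters, which a propionylamino group, with a carbonyl in its place, could help to test.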